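A small aromatic change to compound 1

The compounds below may be only part of what the source reports. "The series", "measured", "known", "first", "only" and "open" are said of these compounds alone.

In an ADME assay on MT2 cells (Homo sapiens) for cytotoxicity, read by XTT assay, with a stated time of 4 days (on this read-out higher numbers stand for lower toxicity in this test and lower numbers for higher toxicity in this test), compound 1 `Cc1ccc(NC(=O)C(=O)NC(c2nc(C)c(CCO)s2)C2CCCCN2)cc1F` gives 85000 nM and compound 2 `Cc1nc(C(NC(=O)C(=O)Nc2ccc(Cl)c(F)c2)C2CCCCN2)sc1CO` gives 77800 nM, two values within the scatter of each other. Compound 3 `Cc1ccc(NC(=O)C(=O)NC(c2nc(C)c(CO)s2)C2CCCCN2)cc1F` reads > 88000 nM, which is a limit of the assay and not a number. Compound 4 `Cc1nc(C(NC(=O)C(=O)Nc2ccc(F)cc2)C2CCCCN2)sc1CCO` keeps the core of compound 1 but carries 4-fluorophenyl in place of 3-fluoro-4-methylphenyl on an amide-type nitrogen. Going by the values given here, no measured step makes this exact change. The closest one, methyl in place of chloro on an aromatic carbon, gives an at least 1.1-fold higher number from compound 2 to compound 3 (0.05 log units; that floor lies within the scatter). Hydroxy in place of hydroxymethyl, at another part of the molecule, gives an at least 1.0-fold higher number from compound 1 to compound 3 (0.01 log units; that floor lies within the scatter). Both steps end at the limit, so each gives only a floor, and neither shows a change beyond the scatter. The expected step is correspondingly small, with a 1.0-fold lower number from compound 1 to compound 4 (0.02 log units; within the scatter), and no shift beyond the scatter is anticipated. The estimated value for compound 4 is 82000 nM, within an expected range of 48000 nM to 135000 nM.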

Compound 4, half-maximal cytotoxic concentration: 109000 nM
Compound 4: middle estimate off by 1.3-fold (0.12 log units), on the low side; the measured number falls inside the stated range.
By their numbers in this assay, from the lowest: compounds 2, 1 and 4 (each within the scatter of the next).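

In this assay, replacing 3-fluoro-4-methylphenyl with 4-fluorophenyl on the amide-type nitrogen gives a 1.3-fold higher number from compound 1 to compound 4 (0.11 log units; within the scatter). This is the first step shown at this position with a true number at both ends, so it measures the size of a change on this aromatic ring instead of setting only a floor. Compound 3 carries a limit of the assay and not a number, which is why its steps could give only floors: the limit of > 88000 nM in this assay, at which 1 of the 4 values shown sits.

The compounds shown leave open whether a group of a different kind on this aromatic ring, such as an amine or a carboxylic acid, would move the number beyond the scatter. Going by these compounds, it also remains open whether a longer chain in place of the ring would do so.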